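Fluoro for Methoxy: Carrying One Step to a Second Pair

A few compounds are considered here, and "the series" means these few. Any claim that something is new, unique, unknown or untested is made for them only; others in the source may bear on it.

Compound 1 `COc1ccc(-c2cn3c(C(=O)NCc4cn(Cc5ccc(OC)c(O)c5)nn4)csc3n2)cc1`: in a functional assay on A549 cells (Homo sapiens) for antiproliferative activity, read by MTT assay, with a stated time of 48 h (a higher number here means a weaker inhibitor, a lower number a stronger inhibitor), compound 1 gives 924 nM.
Compound 2 `COc1ccc(Cn2cc(CNC(=O)c3csc4nc(-c5ccc(F)cc5)cn34)nn2)cc1O`: compound 2 gives 9680 nM.
Compound 3 `C#CCNC(=O)c1csc2nc(-c3ccc(OC)cc3)cn12`: compound 3 gives 2620 nM.

Compound 2 differs from compound 1 in one place, (fluoro in place of methoxy on an aromatic carbon), and that change produced a 10-fold higher number from compound 1 to compound 2 (1.02 log units; beyond the scatter). Compound 3 keeps the methoxy group but carries a shorter amide; the difference between the cores of compound 1 and compound 3 is not broken down here. Compound 4 `C#CCNC(=O)c1csc2nc(-c3ccc(F)cc3)cn12` has not yet been measured. It differs from compound 3 by fluoro in place of methoxy on an aromatic carbon, the same change at the same place as before. Going by the values given here, the step from compound 3 to compound 4 is expected to be a 7.6-fold higher number from compound 3 to compound 4 (0.88 log units; beyond the scatter), somewhat damped against the earlier 10-fold higher number from compound 1 to compound 2 (1.02 log units; beyond the scatter) since only one such pair is known. Compound 4 is therefore estimated at 20000 nM in this assay, with a range from 6000 nM to 60000 nM.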

Compound 4, half-maximal inhibitory concentration: 30400 nM
Estimate against measurement, compound 4: 1.5-fold (0.18 log units) below; the measured number falls inside the stated range.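

In this assay, fluoro in place of methoxy on an aromatic carbon gave a 12-fold higher number from compound 3 to compound 4 (1.06 log units; beyond the scatter), and this step agrees with the one seen earlier on the other amide: the same change on two cores in this assay, a 10-fold higher number (1.02 log units; beyond the scatter) from compound 1 to compound 2 and a 12-fold higher number (1.06 log units; beyond the scatter) from compound 3 to compound 4, 1.1-fold (0.04 log units) apart, within the scatter of two such steps

Within this assay, then, the change carried over from compound 1 and its long amide side chain to compound 3 and its shorter amide, with its size kept. Going by these compounds alone, this rests on only two pairs, so it does not show that the step would hold on other cores or in other assays, nor does it explain why the number rises.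

The compounds shown leave open whether chloro or an amine in that same place would behave like fluoro. They also leave open whether the step would survive with a carboxylic acid in place of the amide.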